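Same aryl swap on two cores: notes on four compounds

The source may hold more compounds than are shown below. What is called first, only, known or untested is meant among the compounds shown, and "the series" means these compounds.

All numbers below come from a functional assay on A549 cells (Homo sapiens) for inhibition, read by MTT assay, with a stated time of 72 h; a higher number here means a weaker inhibitor, a lower number a stronger inhibitor.

compound 1 `O=C(Nc1ccc(Oc2ccnc3[nH]ccc23)cc1)c1cn(-c2ccc(C(F)(F)F)cc2Cl)c2ccccc2c1=O` — 2350 nM
compound 2 `O=C(Nc1ccc(Oc2ccnc3[nH]ccc23)cc1)c1cn(-c2ccc(F)c(Cl)c2)c2ccccc2c1=O` — 4810 nM
compound 3 `Cn1ccc2c(Oc3ccc(NC(=O)c4cn(-c5ccc(C(F)(F)F)cc5Cl)c5ccccc5c4=O)cc3F)ccnc21` — 2050 nM

Compound 1 and compound 2 share one core; compound 2 differs only in that (3-chloro-4-fluorophenyl in place of 2-chloro-4-(trifluoromethyl)phenyl on an aromatic nitrogen). That single change gave a 2.0-fold higher number from compound 1 to compound 2 (0.31 log units; beyond the scatter). Compound 3 sits on a second core; how the core of compound 3 differs from the core of compound 1 is not broken down here. In this assay compound 3 and compound 1 give numbers within the scatter of each other, while compound 2 stands beyond the scatter from compound 3.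

Compound 4 `Cn1ccc2c(Oc3ccc(NC(=O)c4cn(-c5ccc(F)c(Cl)c5)c5ccccc5c4=O)cc3F)ccnc21` is not yet measured. It is compound 3 with 3-chloro-4-fluorophenyl in place of 2-chloro-4-(trifluoromethyl)phenyl on an aromatic nitrogen, and the surroundings of the place are the same as in the move from compound 1 to compound 2, so it is the same change made on the second core. Among the measured compounds shown here, only that one earlier instance is available, so the expectation rests on it alone. For the measured compounds named here, compound 4 is expected to show a 2.0-fold higher number from compound 3 to compound 4 (0.30 log units; within the scatter) in this assay because the earlier 2.0-fold higher number from compound 1 to compound 2 (0.31 log units; beyond the scatter) is the only measured precedent for this change. Compound 4 is therefore estimated at 4100 nM, with an expected range from 2000 nM to 8500 nM.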

Compound 4, half-maximal inhibitory concentration: 1210 nM
Estimate against measurement, compound 4: 3.4-fold (0.53 log units) above, and the stated range ends above it.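

In this assay, the same swap of 2-chloro-4-(trifluoromethyl)phenyl for 3-chloro-4-fluorophenyl on the core of compound 3 gives a 1.7-fold lower number from compound 3 to compound 4 (0.23 log units; within the scatter). The step seen on the core of compound 1 therefore does not carry over unchanged, and the two instances differ: the same change on two cores in this assay, a 2.0-fold higher number (0.31 log units; beyond the scatter) from compound 1 to compound 2 and a 1.7-fold lower number (0.23 log units; within the scatter) from compound 3 to compound 4, 3.5-fold (0.54 log units) apart, beyond the scatter of two such steps. The second step itself lies within the scatter, so this shows that the earlier rise is not repeated, but it does not show a true reversal, and with one pair per core it does not show which difference between the cores matters.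

The compounds shown leave open how the two cores respond to other groups on the aromatic nitrogen, such as a phenyl ring carrying an amine or a carboxylic acid. They also leave open whether the swap follows either of these two outcomes on any further core.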